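The source may report more compounds than this note shows. Statements on the series, on what has been measured and on what is new or still open speak of the compounds shown alone.

Measured so far in an assay on cells for inhibition of interleukin-5 receptor subunit alpha (Mus musculus), read by WST assay, with a stated time of 48 h, tested at 30 uM, in the presence of a further agent that is not named here; a higher number here means more inhibition at the concentration tested (going by the name of the read-out), a lower number less inhibition:
Compound 1, `CCCC(CO)NCc1nc2c(OCC3CCCCC3)cccc2[nH]1`, gives 73.3%.
Compound 2, `COc1ccc(CNCc2nc3c(OCC4CCCCC4)cccc3[nH]2)cc1`, gives 43.3%.

Among the compounds with values here, compound 2 stands lowest of the two numbers measured; its only neighbour is compound 1, and the one measured step is a number 30 percentage points lower from compound 1 to compound 2 (beyond the scatter), in which 4-methoxybenzyl replaced 1-(hydroxymethyl)butyl on an amine nitrogen.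

Compound 3, `c1ccc(NCc2nc3c(OCC4CCCCC4)cccc3[nH]2)cc1`, differs from compound 2 by phenyl in place of 4-methoxybenzyl on an amine nitrogen. The group that leaves here is the very group that entered in the step from compound 1 to compound 2, so that step shows the number can move when this nitrogen carries a different group, but it does not show what a plain phenyl does. Within the data shown here, no measured pair exchanges 4-methoxybenzyl for phenyl, so the direction of the step in this assay is open. Among the measured compounds shown here, since the move at this position so far went downwards, compound 3 is expected to land near or somewhat under compound 2, an estimated 38% with a range from 12% to 64%. This expectation corresponds to a step of a number 5.3 percentage points lower from compound 2 to compound 3 (within the scatter).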

Compound 3, a percentage reported as inhibition, at one concentration (the size of the read-out at that concentration, not a potency): 25%
Compound 3: middle estimate off by 13 percentage points, on the high side, and the stated range covers the measured number.
By their numbers in this assay, from the lowest: compound 3; then compound 2; then compound 1.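

In this assay, exchanging 4-methoxybenzyl for phenyl on the amine nitrogen gives a number 18.3 percentage points lower from compound 2 to compound 3 (beyond the scatter), so these two groups are not interchangeable here, even though each carries one six-membered aromatic ring of carbon only. Within the data shown here, measured against 1-(hydroxymethyl)butyl, phenyl gives a number 48.3 percentage points lower from compound 1 to compound 3 (beyond the scatter), the widest step so far, and with the rest of the molecule unchanged, this single nitrogen substituent accounts for the whole spread among the three compounds. Nothing measured here explains this order.

From the compounds shown here alone, two questions stay open: whether the higher number of compound 1 goes with the hydroxyl of its side chain or with the saturated chain itself, and whether the step from compound 2 to compound 3 goes with the loss of the methoxy group or of the carbon that links the ring to the nitrogen. A plain butyl group on the same nitrogen would speak to the first question, and an unsubstituted benzyl group would speak to the second.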